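Amide substituent change on the shared core

A few compounds are considered here, and "the series" means these few. Any claim that something is new, unique, unknown or untested is made for them only; others in the source may bear on it.

Compound 2 `O=C(Nc1nc(-c2ccccc2)nc2c1nnn2Cc1ccccc1)C1CC1` stands at the lowest of the two numbers measured in an assay (strain Wistar) for displacement of a labelled ligand from adenosine receptor A1 (Rattus norvegicus), read by scintillation counting (a lower number here means a stronger inhibitor, a higher number a weaker inhibitor), giving 7.5 nM. Its nearest neighbour, compound 1 `COc1ccccc1C(=O)Nc1nc(-c2ccccc2)nc2c1nnn2Cc1ccccc1`, gives 1520 nM in this assay. The two differ at one place only, and the step between them is large: a 200-fold lower number from compound 1 to compound 2 (2.31 log units; beyond the scatter).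

Compound 3 `O=C(Nc1nc(-c2ccccc2)nc2c1nnn2Cc1ccccc1)c1cccc(C(F)(F)F)c1` has not yet been measured in this assay. It departs from compound 2 by 3-(trifluoromethyl)phenyl in place of cyclopropyl on a carbonyl carbon. Within the data shown here, the one measured step that bears on this change is the exchange of an aryl group for cyclopropyl on the same carbonyl carbon, which lowered the number by a wide margin. Among the measured compounds shown here, compound 3 runs that exchange in the opposite direction, although the aryl group that enters is not the one that left in compound 1, so the earlier size cannot simply be carried over. For compound 3 an upward step beyond the scatter is expected, smaller than the measured one, a 27-fold higher number from compound 2 to compound 3 (1.43 log units; beyond the scatter). Compound 3 is accordingly estimated at 200 nM in this assay, with a range from 30 nM to 1500 nM.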

Compound 3, inhibition constant: 163 nM
Estimate against measurement, compound 3: 1.2-fold (0.09 log units) above, within the range that was stated.
By their numbers in this assay, from the lowest: compound 2; then compound 3; then compound 1.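

In this assay, a second aryl group on the carbonyl carbon also lies well above cyclopropyl (a 22-fold higher number from compound 2 to compound 3 (1.34 log units; beyond the scatter)), so the low number of compound 2 does not rest on the comparison with 2-methoxyphenyl alone; among the three compounds, none goes against this pattern. The two aryl groups are not interchangeable either, as replacing one with the other still moves the number (a 9.3-fold lower number from compound 1 to compound 3 (0.97 log units; beyond the scatter)), which shows that this position responds to which aryl group it carries and not only to whether an aryl group is present. Nothing shown gives a reason for either step.

The exchange of 2-methoxyphenyl for 3-(trifluoromethyl)phenyl alters the substituent and its place on the ring together, and these two changes cannot be separated with the compounds shown. Also open, going by these compounds, is whether the gap to cyclopropyl follows the aromatic ring or simply the larger group, a question on which an unsubstituted phenyl, a cyclohexyl ring or a straight propyl chain on the same carbonyl carbon would bear.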